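A few compounds are considered here, and "the series" means these few. Any claim that something is new, unique, unknown or untested is made for them only; others in the source may bear on it.

Working notes on the series.

Compound 1 `CC1(C)C/C(=N\NC(N)=O)c2cc(O)ccc2O1` is the reference point. In a functional assay on WI-38 cells (Homo sapiens) for inhibition, with a stated time of 96 h (on this read-out higher numbers stand for weaker inhibition and lower numbers for stronger inhibition), compound 1 gives 140000 nM, the highest of the two numbers recorded so far. Among the compounds with values here, its only neighbour in the set is compound 2 `CCC1(C)C/C(=N\NC(N)=O)c2cc(O)ccc2O1`, which in this assay gives 70000 nM; the step of a 2.0-fold lower number from compound 1 to compound 2 (0.30 log units; within the scatter) is within the scatter, so the two values are read as one level.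

The compound now in question is compound 3 `CC1(C)C/C(=N\NC(N)=S)c2cc(O)ccc2O1`. Relative to compound 1 the change is a group of 3 heavy atoms (1 carbon, 1 nitrogen, 1 sulfur; no ring) in place of a group of 3 heavy atoms (1 carbon, 1 nitrogen, 1 oxygen; no ring), on an amine nitrogen, on an amine nitrogen whose other neighbours are: double-bonded nitrogen. Within the data shown here, no measured step touches this part of the molecule: the single step recorded, a 2.0-fold lower number from compound 1 to compound 2 (0.30 log units; within the scatter), concerns a methyl in place of hydrogen on a saturated chain carbon and says nothing about the carbamoyl. There is therefore no basis in the numbers for expecting a step beyond the scatter in either direction in this assay.

Compound 3 is accordingly expected to give an estimated 110000 nM, with a range of 30000 nM to 400000 nM. The expected step of a 1.3-fold lower number from compound 1 to compound 3 (0.10 log units; within the scatter) is set to lie within the scatter, with a wide range because the measured value for compound 1, 140000 nM, already sits at the weak end of what the assay resolves.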

Compound 3, half-maximal inhibitory concentration: 120000 nM
Estimate against measurement, compound 3: 1.1-fold (0.04 log units) below; low and high end bracket the measured number.
By their numbers in this assay, from the lowest: compounds 2, 3 and 1 (each within the scatter of the next).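

Within the data shown here, this is the first measured change at the carbamoyl on the amine nitrogen, since the earlier step concerned only a saturated chain carbon. In this assay, replacing the carbamoyl with the group of equal heavy-atom count that holds sulfur where the carbamoyl holds oxygen gives a 1.2-fold lower number from compound 1 to compound 3 (0.07 log units; within the scatter), so the two compounds are read as one level and this exchange at this position leaves the read-out within the scatter. Among these compounds, nothing in the material at hand accounts for this result, and the single exchange shows only that the level of compound 1 is kept when sulfur replaces oxygen in this group.

On these data alone, whether the same exchange would also stay within the scatter on the core of compound 2, which carries the added methyl, remains open. Also open, as far as these compounds go, is how the series would respond to a different group on this amine nitrogen, such as an acetyl group, a methyl group or an amidine, any of which could show whether this position can move the read-out beyond the scatter at all.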